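Hydrazone series: pyrrole in place of pyridine

The source may hold more compounds than are shown below. What is called first, only, known or untested is meant among the compounds shown, and "the series" means these compounds.

Two hydrazones built on the shared core have been measured in an assay on isolated protein for inhibition of Amine oxidase [flavin-containing] A (Homo sapiens), read by fluorescence, with stated times of 10 min and 20 min; a lower number here means a stronger inhibitor, a higher number a weaker inhibitor. Compound 1 `CCOc1ccc([N+](=O)[O-])c(N/N=C/c2ccc(C(F)(F)F)cc2)n1` gives 13100 nM in this assay. Compound 2 `CCOc1ccc([N+](=O)[O-])c(N/N=C/c2ccccn2)n1` gives 9520 nM in this assay. Compound 2 and compound 1 sit within the usual scatter of each other, so the two numbers shown do not separate them, and compound 2 cannot be called more or less potent than compound 1.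

Compound 3 `CCOc1ccc([N+](=O)[O-])c(N/N=C/c2cccn2C)n1` is not yet measured. It differs from compound 2 by 1-methyl-1H-pyrrol-2-yl in place of pyridin-2-yl on a carbon with a double bond to nitrogen. Going by the values given here, no measured pair shows this change, so no step can be read from the data; the exchange of one six-membered aromatic ring with one hetero atom for one five-membered aromatic ring with one hetero atom is expected to give no step beyond the scatter in this assay. Compound 3 is therefore expected to give 10000 nM in this assay, within 4000 nM to 25000 nM, an expected step of a 1.1-fold higher number from compound 2 to compound 3 (0.02 log units; within the scatter).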

Compound 3, half-maximal inhibitory concentration: 6120 nM
For compound 3 the middle estimate is 1.6-fold (0.21 log units) above the measured one; measured number inside the range.
By their numbers in this assay, from the lowest: compounds 3, 2 and 1 (each within the scatter of the next, the first and the last beyond it).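

Exchanging pyridin-2-yl for 1-methyl-1H-pyrrol-2-yl on a carbon with a double bond to nitrogen gives a 1.6-fold lower number from compound 2 to compound 3 (0.19 log units; within the scatter) in this assay and so shows that a five-membered aromatic ring with one hetero atom is accepted at this place with no step beyond the scatter. Going by these compounds alone, compound 1 and compound 2 both carry six-membered aromatic rings here, so compound 3 is the first sign that ring size at this place does not separate the compounds in this pair. Nothing available explains why the two rings read alike.

Still open, as far as these compounds go, is whether 1H-pyrrol-2-yl without the methyl, or imidazol-2-yl with a second ring nitrogen, would read like compound 3 in this assay and whether an amine or a carboxylic acid on this ring would give a step beyond the scatter.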